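Acyl swap on the acetoxymethyl oxygen of compound 1

The source may report more compounds than this note shows. Statements on the series, on what has been measured and on what is new or still open speak of the compounds shown alone.

Measured so far in a functional assay on A549 cells (Homo sapiens) for antiproliferative activity, read by MTT assay, with a stated time of 48 h; a lower number here means a stronger inhibitor, a higher number a weaker inhibitor:
compound 1 `CC(=O)OC/C1=C/C[C@](C)(CCC=C(C)C)/C=C/[C@@H](OC(=O)C=C(C)C)[C@](C)(O)/C=C/C1=O` gives 2950 nM.
compound 2 `CC(C)=CCC[C@]1(C)/C=C/[C@@H](OC(=O)C=C(C)C)[C@](C)(O)/C=C/C(=O)/C(C(=O)O)=C\C1` gives > 10000 nM, which is a limit of the assay.
compound 3 `CC(C)=CCC[C@]1(C)/C=C/[C@@H](OC(=O)C=C(C)C)[C@](C)(O)/C=C/C(=O)/C(Cn2cc(CO)nn2)=C\C1` gives 3470 nM.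

Compound 1 holds the lowest of the two numbers shown, with compound 3 close by at a 1.2-fold higher number from compound 1 to compound 3 (0.07 log units; within the scatter); the value of compound 2 is only a limit (the limit of > 10000 nM in this assay, at which 1 of the 3 values shown sits). Compound 4 `CSC(=S)OC/C1=C/C[C@](C)(CCC=C(C)C)/C=C/[C@@H](OC(=O)C=C(C)C)[C@](C)(O)/C=C/C1=O` keeps the core of compound 1 and differs only here: a group of 4 heavy atoms (2 carbon, 2 sulfur; no ring) in place of a group of 3 heavy atoms (2 carbon, 1 oxygen; no ring), on an oxygen on a saturated carbon. The change keeps the ester oxygen and alters only the group on it. Among the measured compounds shown here, the step bearing most is the one to compound 3, within the scatter, where the whole acetoxy group was exchanged on the same saturated chain carbon. The step of an at least 3.3-fold higher number from compound 1 to compound 2 (0.53 log units; beyond the scatter), where the acetoxymethyl itself gave way to carboxy, went the other way. With the oxygen retained, the step of a 1.0-fold higher number from compound 1 to compound 4 (0.01 log units; within the scatter) is expected to remain within the scatter. Compound 4 is therefore estimated at 3000 nM, within 1200 nM to 7500 nM.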

Compound 4, half-maximal inhibitory concentration: 380 nM
For compound 4 the middle estimate is 7.9-fold (0.90 log units) above the measured one; the whole stated range lies above it.
By their numbers in this assay, from the lowest: compound 4; then compounds 1 and 3 (each within the scatter of the next). At a limit, above all of these: compound 2.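

In this assay, the group on the oxygen of this saturated carbon proves not to be silent: a 7.8-fold lower number from compound 1 to compound 4 (0.89 log units; beyond the scatter), although the exchange of the whole acetoxy group for the triazole stayed within the scatter. Against 4-(hydroxymethyl)-1H-1,2,3-triazol-1-yl the gap is a 9.1-fold lower number from compound 3 to compound 4 (0.96 log units; beyond the scatter), and against carboxy it is an at least 26-fold lower number from compound 2 to compound 4 (1.42 log units; beyond the scatter). That last step rests on a limit, not a number: the limit of > 10000 nM in this assay, at which 1 of the 4 values shown sits.

Open, on these data alone, is whether the sulfur atoms or the larger entering group carries the step. A methyl carbonate, or a longer chain on the sulfur, would separate the two.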